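The compounds below may be only part of what the source reports. "The series", "measured", "known", "first", "only" and "open" are said of these compounds alone.

Compound 1 `COc1ccc(Cn2cc(CSc3nnc(-c4ccccc4)c(-c4ccccc4)n3)nn2)cc1`: 27500 nM
Compound 2 `O=c1ccc2ccc(OCCCn3cc(CSc4nnc(-c5ccccc5)c(-c5ccccc5)n4)nn3)cc2o1`: 92300 nM

Both were tested in a functional assay on PC-3 cells (Homo sapiens) for antiproliferative activity, read by MTT assay, with a stated time of 48 h; a lower number here means a stronger inhibitor, a higher number a weaker inhibitor. Compound 2 has the highest number of the two; compound 1 sits lower by a gap beyond the usual scatter, so compound 2 is the weaker inhibitor of this pair. Compound 3 `O=c1cc(OCCCn2cc(CSc3nnc(-c4ccccc4)c(-c4ccccc4)n3)nn2)c2ccccc2o1` differs from compound 2 by a group of 11 heavy atoms (9 carbon, 2 oxygen; one six-membered aromatic ring of carbon only, one six-membered aromatic ring with 1 hetero atom) in place of a group of 11 heavy atoms (9 carbon, 2 oxygen; one six-membered aromatic ring of carbon only, one six-membered aromatic ring with 1 hetero atom), on an oxygen on a saturated carbon. Among the compounds with values here, no measured pair shows how such a rearrangement moves the number in this assay, so the estimated step is a 1.2-fold lower number from compound 2 to compound 3 (0.09 log units; within the scatter), no more than the scatter, in no sure direction. Compound 3 is therefore expected to give about 75000 nM, with a range from 25000 nM to 200000 nM.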

Compound 3, half-maximal inhibitory concentration: 57800 nM
The estimate for compound 3 lay 1.3-fold (0.11 log units) above the measured number, and the stated range covers the measured number.
By their numbers in this assay, from the lowest: compound 1; then compounds 3 and 2 (each within the scatter of the next).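

In this assay, joining the same atoms differently within the group on this oxygen gives a 1.6-fold lower number from compound 2 to compound 3 (0.20 log units; within the scatter), so compound 2 and compound 3 cannot be told apart here. This is the first pair shown that differs in one place, and it indicates that this rearrangement of the group makes no clear difference to the number. Nothing measured here explains that result. From the compounds shown here alone, it remains open whether an amine or a carboxylic acid in place of this group would move the number beyond the scatter. Going by these compounds, the effect of a longer chain also remains open.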